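Swapping a propyl chain for a phenyl ring

A few compounds are considered here, and "the series" means these few. Any claim that something is new, unique, unknown or untested is made for them only; others in the source may bear on it.

Compound 1, `Cc1ccc(S(=O)(=O)N(Nc2ccccc2)C(=O)Oc2ccccc2)cc1`: 5720 nM
Compound 2, `CCCc1ccc(S(=O)(=O)N(Nc2ccccc2)C(=O)Oc2ccc(Oc3ccccc3)cc2)cc1`: 134 nM

Both numbers come from a functional assay on RAW264.7 cells (Mus musculus), read by immunoassay, with a stated time of 24 h; a lower number here means a stronger inhibitor, a higher number a weaker inhibitor. Compound 2 stands lowest of the two, and compound 1 sits well beyond the scatter above it. Compound 3, `O=C(Oc1ccc(Oc2ccccc2)cc1)N(Nc1ccccc1)S(=O)(=O)c1ccc(-c2ccccc2)cc1`, differs from compound 2 by phenyl in place of propyl on an aromatic carbon. Within the data shown here, no pair of measured compounds shows this change on its own, so no measured step points to a direction. The expected step from compound 2 to compound 3 in this assay is a 1.2-fold higher number from compound 2 to compound 3 (0.08 log units; within the scatter), small and plausibly within the scatter. Compound 3 is therefore estimated at 160 nM, with a range from 50 nM to 500 nM.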

Compound 3, half-maximal inhibitory concentration: 161 nM
For compound 3 the middle estimate is 1.0-fold (0.00 log units) below the measured one, and the stated range covers the measured number.
By their numbers in this assay, from the lowest: compounds 2 and 3 (each within the scatter of the next); then compound 1.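

In this assay, the change from 4-propylphenyl to 4-phenylphenyl gives a 1.2-fold higher number from compound 2 to compound 3 (0.08 log units; within the scatter), so the two compounds cannot be told apart. This position therefore accepts an aromatic ring of six heavy atoms as well as a three-carbon chain without a measurable change in inhibition. Nothing available explains why the two groups give such similar results.

On these data alone, it remains open whether this tolerance extends to a longer chain, such as hexyl, or to a group carrying an amine or a carboxylic acid.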